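The source may report more compounds than this note shows. Statements on the series, on what has been measured and on what is new or still open speak of the compounds shown alone.

Measured so far in an assay on SK-OV-3 cells for inhibition of Indoleamine 2,3-dioxygenase 1 (Homo sapiens); a higher number here means a weaker inhibitor, a lower number a stronger inhibitor:
- compound 1, `NS(=O)(=O)NCCCNC(=O)/C(=N/O)Nc1ccc(F)c(Cl)c1`, 1200 nM
- compound 2, `O=C(Nc1ccc(F)c(Cl)c1)C(=O)N1CCC(c2ccccc2)CC1`, 1800 nM

In this assay compound 2 gives 1800 nM and compound 1 gives 1200 nM; the two numbers lie within the usual scatter of each other, so neither stands apart on the numbers shown. Compound 3, `O=C(Nc1ccc(Cl)cc1)C(=O)N1CCC(c2ccccc2)CC1`, is not yet measured. It differs from compound 2 in one place: 4-chlorophenyl in place of 3-chloro-4-fluorophenyl on an amide-type nitrogen. Among the measured compounds shown here, no measured pair shows this change, so its size is unknown; a step no larger than the scatter is expected, if anything towards a weaker inhibitor. The estimated step from compound 2 to compound 3 is a 1.4-fold higher number from compound 2 to compound 3 (0.14 log units; within the scatter). Compound 3 is expected to give about 2500 nM, in the range 1000 nM to 6000 nM.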

Compound 3, half-maximal inhibitory concentration: 90 nM
Estimate against measurement, compound 3: 28-fold (1.44 log units) above; the whole stated range lies above it.
By their numbers in this assay, from the lowest: compound 3; then compounds 1 and 2 (each within the scatter of the next).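

In this assay 4-chlorophenyl in place of 3-chloro-4-fluorophenyl on an amide-type nitrogen brings a 20-fold lower number from compound 2 to compound 3 (1.30 log units; beyond the scatter) and the rest of the compound stays unchanged. This aryl group therefore has a strong hold on the number, and a small edit to it can matter far more than compound 1 and compound 2 suggested. Among the compounds shown here, with only one such pair, this holds for this single change alone.

Going by these compounds, whether a plain phenyl, or an amine or a carboxylic acid in place of the chlorine, would keep this gain remains open. Nothing measured here explains the size of the step.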